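A few compounds are considered here, and "the series" means these few. Any claim that something is new, unique, unknown or untested is made for them only; others in the source may bear on it.

Measured so far:
compound 1 `Cc1ccsc1/C=C(/SCc1ccc(F)cc1)C(=O)c1ccc(Br)cc1` — 50000 nM
compound 2 `O=C(/C(=C\c1ccc(I)cc1)S(=O)(=O)c1ccc(Br)cc1)c1ccc(Br)cc1` — 1000 nM

Of the compounds shown here, two have been measured in a functional assay on DU-145 cells (Homo sapiens) for inhibition, read by trypan blue exclusion, with a stated time of 96 h; a lower number here means a stronger inhibitor of growth, a higher number a weaker inhibitor of growth. Compound 1 `Cc1ccsc1/C=C(/SCc1ccc(F)cc1)C(=O)c1ccc(Br)cc1` gives 50000 nM in this assay. Compound 2 `O=C(/C(=C\c1ccc(I)cc1)S(=O)(=O)c1ccc(Br)cc1)c1ccc(Br)cc1` gives 1000 nM in this assay. Compound 2 thus stands with the lowest number of the two, and the gap up to compound 1 lies beyond the usual scatter of repeated measurements. Within the data shown here, no single-point step between measured compounds is available, so nothing is known yet about how a change at one place alone moves the number.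

The next compound, compound 3 `O=C(/C(=C\c1ccc(F)cc1Cl)S(=O)(=O)c1ccc(Br)cc1)c1ccc(Br)cc1`, differs from compound 2 in one place: 2-chloro-4-fluorophenyl in place of 4-iodophenyl on a double-bonded chain carbon bound to a double-bonded chain carbon. The rest of the shared core is unchanged.

Among the measured compounds shown here, with no comparable step on record, the expectation rests on compound 2 alone. Compound 3 is expected to land near compound 2, with a small drift toward a higher number that may or may not exceed the scatter. The step that this estimate means is a 2.0-fold higher number from compound 2 to compound 3 (0.30 log units; within the scatter), expected to be modest. Compound 3 is estimated at 2000 nM, with a range from 500 nM to 8000 nM.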

Compound 3, concentration for 50% growth inhibition: 50000 nM
Beside the measured number, compound 3's estimate is 25-fold (1.40 log units) below it; the measured number lies above the stated range.
By their numbers in this assay, from the lowest: compound 2; then compounds 1 and 3 (each within the scatter of the next).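

In this assay, among these compounds, putting 2-chloro-4-fluorophenyl in place of 4-iodophenyl on a double-bonded chain carbon bound to a double-bonded chain carbon brings a 50-fold higher number from compound 2 to compound 3 (1.70 log units; beyond the scatter), and this is the first change at a single place whose effect can be read. It shows that this position is not indifferent: with the rest of the shared core unchanged, the aryl group at this place can by itself separate a compound with a clearly lower number from one with a much weaker effect on growth. Nothing measured here bears on why the number moves so far.

The change removes iodine and brings in chlorine and fluorine in one step, so the compounds shown do not tell whether the loss goes with the departure of the iodine, the arrival of the chlorine, the arrival of the fluorine or some combination of these. From the compounds shown here alone, it also remains open whether a plain phenyl, or an aryl group carrying an amine or a carboxylic acid, would stay close to compound 2 or move as far as compound 3 at this place.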